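Swapping the Benzyl Arm of Compound 3 for an Anilino Group

The source may hold more compounds than are shown below. What is called first, only, known or untested is meant among the compounds shown, and "the series" means these compounds.

Three compounds share one core and differ only in the arm on the five-membered aromatic ring. In a functional assay on CHO cells for antagonist activity at prostaglandin E2 receptor EP1 subtype (Homo sapiens), read by FLIPR and calcium flux (on this read-out lower numbers stand for stronger inhibition and higher numbers for weaker inhibition), compound 1 `Cc1ccc(S(=O)(=O)N(Cc2nnc(Cc3ccc(N(C)C)cc3)o2)c2cccc(Cl)c2C)cc1` gives 20 nM, compound 2 `Cc1ccc(S(=O)(=O)N(Cc2nnc(Cc3ccc(C(F)(F)F)cc3)o2)c2cccc(Cl)c2C)cc1` gives 158 nM, and compound 3 `Cc1ccc(S(=O)(=O)N(Cc2nnc(Cc3ccccc3Cl)o2)c2cccc(Cl)c2C)cc1` gives 398 nM, the highest of the three numbers. The steps into compound 3 were a 20-fold higher number from compound 1 to compound 3 (1.30 log units; beyond the scatter) and a 2.5-fold higher number from compound 2 to compound 3 (0.40 log units; beyond the scatter), so this position has moved the read-out by a large amount. Compound 4 `COc1ccc(Nc2nnc(CN(c3cccc(Cl)c3C)S(=O)(=O)c3ccc(C)cc3)o2)cc1` carries (4-methoxyphenyl)amino in place of 2-chlorobenzyl on an aromatic carbon. Among the measured compounds shown here, no measured step exchanges a benzyl for an amino-linked aryl, so the direction can be read only from the sensitivity of this position. Compound 4 is therefore expected at 150 nM, within 30 nM to 800 nM, which would mean a 2.7-fold lower number from compound 3 to compound 4 (0.42 log units; beyond the scatter).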

Compound 4, inhibition constant: 79.4 nM
Estimate against measurement, compound 4: 1.9-fold (0.28 log units) above; low and high end bracket the measured number.
By their numbers in this assay, from the lowest: compound 1; then compounds 4 and 2 (each within the scatter of the next); then compound 3.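

At this position on the shared core, an arm joined through an amino group rather than a saturated carbon still gives inhibition in this assay, with a 5.0-fold lower number from compound 3 to compound 4 (0.70 log units; beyond the scatter). It stands level with the 4-(trifluoromethyl)benzyl arm, with a 2.0-fold lower number from compound 2 to compound 4 (0.30 log units; within the scatter), but falls short of the 4-(dimethylamino)benzyl arm, with a 4.0-fold higher number from compound 1 to compound 4 (0.60 log units; beyond the scatter). No evidence is available here to explain these differences. The compounds shown leave open how much of the gain belongs to the amino link and how much to the ring substituent: a 4-methoxybenzyl arm would separate the two.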